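Carbamate aryl substituent: fluoro to methyl on the shared core

The source may report more compounds than this note shows. Statements on the series, on what has been measured and on what is new or still open speak of the compounds shown alone.

Measured so far:
compound 1 `COc1ccc(OC(=O)Nc2ccc([Se]C#N)cc2)cc1` — in a functional assay on MCF7 cells (Homo sapiens) for cytotoxicity, read by MTT assay, with a stated time of 72 h (a lower number here means a stronger inhibitor of growth, a higher number a weaker inhibitor of growth), compound 1 gives 22400 nM
compound 2 `N#C[Se]c1ccc(NC(=O)Oc2ccc(F)cc2)cc1` — in this assay compound 2 gives 8300 nM

Going by the values given here, compound 2 holds the lowest of the two numbers; its nearest neighbour is compound 1, and the single measured step, a 2.7-fold lower number from compound 1 to compound 2 (0.43 log units; beyond the scatter), is the only comparison available. Compound 3 `Cc1ccc(OC(=O)Nc2ccc([Se]C#N)cc2)cc1` is not yet measured. It differs from compound 2 by methyl in place of fluoro on an aromatic carbon. Among the compounds with values here, no measured pair shows methyl against fluoro at this position, so the methoxy-to-fluoro step is the only guide, and it points to the fluoro compound holding the lower number of the two measured. For compound 3 the expected step is a 1.4-fold higher number from compound 2 to compound 3 (0.16 log units; within the scatter), towards a higher number but of a size that may sit within the scatter. The estimate for compound 3 in this assay is 12000 nM, with a range from 5000 nM to 30000 nM.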

Compound 3, concentration for 50% growth inhibition: 9900 nM
Compound 3: the middle estimate sits 1.2-fold (0.08 log units) above what was measured, within the range that was stated.
By their numbers in this assay, from the lowest: compounds 2 and 3 (each within the scatter of the next); then compound 1.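

In this assay, the change from fluoro to methyl gives a 1.2-fold higher number from compound 2 to compound 3 (0.08 log units; within the scatter) and so does not separate these two groups at this position. Replacing methoxy with methyl gives a 2.3-fold lower number from compound 1 to compound 3 (0.35 log units; beyond the scatter) and, like a 2.7-fold lower number from compound 1 to compound 2 (0.43 log units; beyond the scatter), lies beyond the scatter, so the earlier gain is not confined to fluoro: among the three groups shown, methoxy alone stands apart, with compound 1 at the higher number. Nothing available explains this grouping of the three compounds.

The compounds shown leave open how an amine, a carboxylic acid or a longer chain would read at this position on the shared core. They also leave open whether plain hydrogen here would fall with methyl and fluoro or with methoxy.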